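Bromo for hydrogen: a second pair in the series

A few compounds are considered here, and "the series" means these few. Any claim that something is new, unique, unknown or untested is made for them only; others in the source may bear on it.

Compound 1 `C/C(=N\NC(=O)COc1cccc2ccccc12)c1ccccc1` and compound 2 `C/C(=N\NC(=O)COc1cccc2ccccc12)c1ccccc1Br` differ by bromo in place of hydrogen on an aromatic carbon. In a physicochemical assay for lipophilicity, measured as octanol-water partition (a higher number here means a more lipophilic compound, a lower number a more polar compound), compound 1 gives 3.65 and compound 2 gives 4.44, a step of a number 0.79 log units higher from compound 1 to compound 2 (beyond the scatter). Compound 3 `O=C(COc1cccc2ccccc12)N/N=C/c1ccccc1` gives 4.02 in this assay; the difference between the cores of compound 1 and compound 3 is not broken down here. Compound 4 `O=C(COc1cccc2ccccc12)N/N=C/c1cccc(Br)c1` differs from compound 3 by bromo in place of hydrogen on an aromatic carbon. This is the same kind of change as that from compound 1 to compound 2, not the same: there the bromo sits ortho to a large group, here meta to a large group. From compound 3 to compound 4 a step of a number 0.78 log units higher from compound 3 to compound 4 (beyond the scatter) is expected in this assay, resting on the step of a number 0.79 log units higher from compound 1 to compound 2 (beyond the scatter) measured for the same kind of change. Compound 4 is therefore estimated at 4.8 in this assay, between 4.5 and 5.1.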

Compound 4, partition coefficient: 4.81
Compound 4: the middle estimate sits 0.01 log units below what was measured; measured number inside the range.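

In this assay the change of hydrogen to bromo reads a number 0.79 log units higher from compound 3 to compound 4 (beyond the scatter) against a number 0.79 log units higher from compound 1 to compound 2 (beyond the scatter) on the other core, so in these two pairs the step carries across the cores at a closely matching size. Two pairs do not make a rule for the series, and the bromo in compound 4 is meta to a large group while in compound 2 it stands elsewhere, so the effects of core and place are not separated. Nothing available explains the size of the step.

Open, as far as these compounds go, is whether an amine or a carboxylic acid in place of the bromo would carry between the cores in the same way. Also open, from the compounds shown here alone, is how far the match holds on further cores.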